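Isobutyl for Isopropyl on the Ether Oxygen

The source may hold more compounds than are shown below. What is called first, only, known or untested is meant among the compounds shown, and "the series" means these compounds.

Three compounds have been measured in a functional assay on DU-145 cells (Homo sapiens) for antiproliferative activity, read by sulforhodamine B assay, with a stated time of 72 h; on this read-out lower numbers stand for stronger inhibition of growth and higher numbers for weaker inhibition of growth:
compound 1, `CCc1cc(=O)c2ccc(OCC(C)C)c(CBr)c2o1`, gives > 29400 nM, which is a limit of the assay and not a number.
compound 2, `CCOc1ccc2c(=O)cc(C(C)Br)oc2c1CBr`, gives 20900 nM.
compound 3, `CC(C)Oc1ccc2c(=O)cc(C(C)Br)oc2c1CBr`, gives 15500 nM.

Compound 3 sits at the lowest of the two numbers, and compound 2 lies close to it: the step is a 1.3-fold lower number from compound 2 to compound 3 (0.13 log units; within the scatter). Compound 4, `CC(C)COc1ccc2c(=O)cc(C(C)Br)oc2c1CBr`, differs from compound 3 by isobutyl in place of isopropyl on an oxygen on an aromatic ring. Going by the values given here, only one measured step touches the same oxygen, namely a 1.3-fold lower number from compound 2 to compound 3 (0.13 log units; within the scatter), which stayed within the scatter. Among the compounds with values here, compound 1 also carries an isobutyl group on that oxygen, but it differs from compound 4 in another place as well, so its value shows only that such a compound can sit at the limit (the limit of > 29400 nM in this assay, at which 1 of the 3 values shown sits). Within the data shown here, since the one comparable step was small, the step to compound 4 is expected to be a 1.1-fold lower number from compound 3 to compound 4 (0.04 log units; within the scatter), not beyond the scatter. Compound 4 is therefore estimated at 14000 nM, with a range from 6000 nM to 30000 nM.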

Compound 4, concentration for 50% growth inhibition: 10500 nM
The estimate for compound 4 lay 1.3-fold (0.12 log units) above the measured number; the measured number falls inside the stated range.
By their numbers in this assay, from the lowest: compounds 4, 3 and 2 (each within the scatter of the next). At a limit, above all of these: compound 1.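

In this assay, isobutyl on this oxygen does not move the number beyond the scatter: the change itself gives a 1.5-fold lower number from compound 3 to compound 4 (0.17 log units; within the scatter), and the widest pair of ether groups shown gives a 2.0-fold lower number from compound 2 to compound 4 (0.30 log units; within the scatter), so all three compounds carrying the bromo on the chain remain within the scatter of their neighbours. The step that does pass the scatter lies in another place, bromo in place of hydrogen on a saturated chain carbon, and it reads an at least 2.8-fold lower number from compound 1 to compound 4 (0.44 log units; beyond the scatter). Compound 1 stands at a limit of the assay and not at a number: the limit of > 29400 nM in this assay, at which 1 of the 4 values shown sits.

The compounds shown leave open whether a longer chain, or an amine at the end of the chain on this oxygen, would stay in the same range. On these data alone, the true size of the bromo step also remains open, since only a lower bound on it can be read.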